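The source may report more compounds than this note shows. Statements on the series, on what has been measured and on what is new or still open speak of the compounds shown alone.

Measured compounds:
compound 1 `COc1ccc(/C=C/c2cc(OC)cc(OC)c2/C=C/C(=O)c2cc3cc(OC)ccc3oc2=O)cc1` — > 60000 nM
compound 2 `COc1ccc(/C=C/c2cc(OC)cc(OC)c2/C=C/C(=O)c2cc3cc(Br)cc(OC)c3oc2=O)cc1` — > 60000 nM
compound 3 `COc1ccc(/C=C/c2cc(OC)cc(OC)c2/C=C/C(=O)c2cc3cc(F)ccc3oc2=O)cc1` — 44300 nM

In an assay on isolated protein for inhibition of Amine oxidase [flavin-containing] A (Homo sapiens), read by fluorescence, with a stated time of 15 min (on this read-out higher numbers stand for weaker inhibition and lower numbers for stronger inhibition), compound 1 reaches only the limit of the assay, > 60000 nM, and no number. Compound 2 likewise sits at the limit, > 60000 nM. Compound 3 alone gives a number in this assay, 44300 nM. The step of an at least 1.3-fold lower number from compound 1 to compound 3 (0.13 log units; that floor lies within the scatter) is therefore not known in full, and what is known of it lies within the scatter. Two of the three values sit at the limit of > 60000 nM in this assay, at which 2 of the 3 values shown sit, so compound 1 stands among the compounds for which this assay gives nothing more than a limit.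

The new compound 4 `COc1ccc(/C=C/c2cc(OC)cc(OC)c2/C=C/C(=O)c2cc3cc(C)ccc3oc2=O)cc1` differs from compound 1 by methyl in place of methoxy on an aromatic carbon. Among the compounds with values here, the only measured step that bears on this position is the step from compound 1 to compound 3, where fluoro replaced methoxy, and it is too small to separate from the scatter. Within the data shown here, nothing among the measured compounds shows that a change at this carbon moves the read-out beyond the scatter, and methyl has not been tried at it. In this assay compound 4 is therefore expected to stay near the limit, and the step of a number no higher from compound 1 to compound 4 (the limit leaves the size open) is expected to be no larger than the scatter. Compound 4 is estimated at 60000 nM, with a range from 20000 nM to 200000 nM.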

Compound 4, half-maximal inhibitory concentration: 30400 nM
Estimate against measurement, compound 4: 2.0-fold (0.30 log units) above, and the stated range covers the measured number.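

At this aromatic carbon, meta to a fused ring and para to a fused ring, compound 4 adds a second measured number in this assay, so two groups can now be compared here without a limit on either side, and methyl in place of fluoro gives a 1.5-fold lower number from compound 3 to compound 4 (0.16 log units; within the scatter). Fluoro and methyl are therefore not told apart at this carbon. Methyl in place of methoxy gives an at least 1.9-fold lower number from compound 1 to compound 4 (0.29 log units; that floor lies within the scatter), and the size of this step stays open because compound 1 has only a limit and no number, so the step may be larger than its floor: the limit of > 60000 nM in this assay, at which 2 of the 4 values shown sit.

From the compounds shown here alone, whether an amine, a carboxylic acid or a longer chain at this carbon would move the read-out beyond the scatter from compound 3 and compound 4 remains open. Going by these compounds, it also remains open whether methoxy truly differs from fluoro or methyl here, and whether a change at any other place on the shared core would have a larger effect than the changes at this carbon.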